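A few compounds are considered here, and "the series" means these few. Any claim that something is new, unique, unknown or untested is made for them only; others in the source may bear on it.

Measured in a functional assay on A549 cells (Homo sapiens) for cytotoxicity, with a stated time of 48 h; on this read-out lower numbers stand for stronger inhibition and higher numbers for weaker inhibition:
compound 1 `CC(C)COc1ccc2oc(/C=C/[S+](C)[O-])cc(=O)c2c1`: 1100 nM
compound 2 `CC(C)CC(=O)Oc1ccc2oc(/C=C/[S+](C)[O-])cc(=O)c2c1`: 2300 nM

Of these two, compound 2 has the higher number, at 2300 nM. Compound 3 `Cc1ccc2oc(/C=C/[S+](C)[O-])cc(=O)c2c1` has methyl in place of (isobutylcarbonyl)oxy on an aromatic carbon. Among the compounds with values here, the one measured step bearing on this is a 2.1-fold higher number from compound 1 to compound 2 (0.32 log units; beyond the scatter). It is modest and keeps the oxygen on the aromatic ring, which compound 3 lacks, so it gives no firm direction. No step beyond the scatter is therefore expected in this assay. The estimated change is a 1.1-fold higher number from compound 2 to compound 3 (0.04 log units; within the scatter). For compound 3 the expected value is 2500 nM, with an estimated range of 900 nM to 7000 nM.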

Compound 3, half-maximal inhibitory concentration: 1700 nM
Compound 3: the middle estimate sits 1.5-fold (0.17 log units) above what was measured; the measured number falls inside the stated range.
By their numbers in this assay, from the lowest: compounds 1, 3 and 2 (each within the scatter of the next, the first and the last beyond it).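

In this assay methyl in place of (isobutylcarbonyl)oxy gives a 1.4-fold lower number from compound 2 to compound 3 (0.13 log units; within the scatter) and methyl in place of isobutoxy gives a 1.5-fold higher number from compound 1 to compound 3 (0.19 log units; within the scatter). Within the data shown here, both steps lie within the scatter, so on this aromatic carbon neither the oxygen nor the chain of the earlier compounds is needed for a number in this range. No measurement at hand explains this result.

The compounds shown leave open whether an amine, a carboxylic acid or a longer chain on this carbon would move the number beyond the scatter. They also leave open what a bare hydrogen there would give.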